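Swapping methoxy for chloro on compound 1

A few compounds are considered here, and "the series" means these few. Any claim that something is new, unique, unknown or untested is made for them only; others in the source may bear on it.

Measured in a functional assay on HL-60 cells (Homo sapiens) for inhibition, read by CCK-8 assay, with a stated time of 48 h, tested at 20 uM; a higher number here means more inhibition of growth at the concentration tested, a lower number less inhibition of growth:
Compound 1 `COc1ccc(Cc2nnc(NC(=O)/C(C#N)=C/c3ccccc3OS(=O)(=O)c3ccc([N+](=O)[O-])cc3)s2)cc1`: 51%
Compound 2 `COc1ccc(Cc2nnc(NC(=O)/C(C#N)=C/c3ccccc3OS(=O)(=O)c3ccc(Cl)cc3)s2)cc1`: 20%

Of these two, compound 1 stands highest in this assay. Compound 3 `N#C/C(=C\c1ccccc1OS(=O)(=O)c1ccc([N+](=O)[O-])cc1)C(=O)Nc1nnc(Cc2ccc(Cl)cc2)s1` has chloro in place of methoxy on an aromatic carbon, para to a large group (chloro in place of methoxy on an aromatic carbon). Among the measured compounds shown here, the only measured step, a number 31 percentage points lower from compound 1 to compound 2 (beyond the scatter), is a large one, but it lies elsewhere in the structure. It shows that a single swap can matter, yet it gives no direction here, so no change beyond the scatter is expected. The estimated change is a number 3 percentage points lower from compound 1 to compound 3 (within the scatter). For compound 3 the expected value is 48%, with an estimated range of 25% to 70%.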

Compound 3, percent growth inhibition at one concentration: 34%
Estimate against measurement, compound 3: 14 percentage points above, and the stated range covers the measured number.
By their numbers in this assay, from the lowest: compound 2; then compound 3; then compound 1.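

The para position on the benzyl ring is not indifferent in this assay: chloro in place of methoxy gives a number 17 percentage points lower from compound 1 to compound 3 (beyond the scatter). So the 4-methoxybenzyl group, like the nitro group changed in the earlier step, is a place where a single swap moves growth inhibition beyond the scatter, and compound 1 stays above both of its one-place neighbours. Nothing available explains this drop. Going by these compounds, it remains open whether an amine, a hydroxyl or a longer ether chain at this position would keep or lose the inhibition, and whether the same swap would act alike on compound 2.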